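Benzoxazole to quinoxaline swap in a lipoxygenase series

This account rests on a few compounds, and the source may have more. Where it says the series, first, only, none or still open, it means among the compounds named here.

In a functional assay for inhibition of Polyunsaturated fatty acid 5-lipoxygenase (Homo sapiens) (on this read-out lower numbers stand for stronger inhibition and higher numbers for weaker inhibition), compound 1 `O=C(O)/C=N/OC(c1ccc(OCc2nc3cc(F)ccc3s2)cc1)C1CCCCC1` gives 87 nM. Compound 2 `O=C(O)/C=N/OC(c1ccc(OCc2nc3ccccc3o2)cc1)C1CCCCC1` differs by a 1.6-fold higher number from compound 1 to compound 2 (0.22 log units; within the scatter), and in this assay compound 2 gives 143 nM. Compound 3 `O=C(O)/C=N/OC(c1ccc(OCc2cnc3ccccc3n2)cc1)C1CCCCC1` carries quinoxalin-2-yl in place of 1,3-benzoxazol-2-yl on a saturated chain carbon bound to an oxygen on an aromatic ring. Among the measured compounds shown here, the only step that bears on this change is the one from compound 1 to compound 2, an exchange of the bicyclic heteroaryl at the same place that stayed within the scatter. For the step from compound 2 to compound 3 a change of a 1.0-fold higher number from compound 2 to compound 3 (0.02 log units; within the scatter) is therefore expected, with no direction claimed beyond the scatter. Compound 3 is estimated at 150 nM in this assay, within 60 nM to 400 nM.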

Compound 3, half-maximal inhibitory concentration: 25 nM
For compound 3 the middle estimate is 6.0-fold (0.78 log units) above the measured one; measured number outside the range, below it.
By their numbers in this assay, from the lowest: compound 3; then compounds 1 and 2 (each within the scatter of the next).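

The heteroaryl at this place is not interchangeable in this assay: quinoxalin-2-yl gives a gain over 1,3-benzoxazol-2-yl (a 5.7-fold lower number from compound 2 to compound 3 (0.76 log units; beyond the scatter)) and over 5-fluoro-1,3-benzothiazol-2-yl (a 3.5-fold lower number from compound 1 to compound 3 (0.54 log units; beyond the scatter)). Both steps lie beyond the scatter, whereas the exchange between the two earlier groups did not, so quinoxalin-2-yl stands apart from both. No measurement shown accounts for this gain. Still open, going by these compounds, is whether the six-membered ring with two hetero atoms is required, or whether a quinolin-2-yl group, with a single ring nitrogen, would match quinoxalin-2-yl.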